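Phenyl substituent exchange in the urea-linked series

The source may hold more compounds than are shown below. What is called first, only, known or untested is meant among the compounds shown, and "the series" means these compounds.

Of the compounds shown here, three of the shared core have been measured. Compound 1 `COc1cc(NC(C)CCCNC(=O)Nc2ccc(F)cc2)c2ncccc2c1` gives 20000 nM in a functional assay on HeLa cells (Homo sapiens) for inhibition, read by MTT assay, with a stated time of 72 h; on this read-out lower numbers stand for stronger inhibition and higher numbers for weaker inhibition. Compound 2 `COc1cc(NC(C)CCCNC(=O)Nc2ccc(C(F)(F)F)cc2)c2ncccc2c1` gives 8300 nM in this assay, a step of a 2.4-fold lower number from compound 1 to compound 2 (0.38 log units; beyond the scatter). Compound 3 `COc1cc(NC(C)CCCNC(=O)Nc2cccc(Cl)c2)c2ncccc2c1` gives 17000 nM in this assay and so stands second highest of the three numbers; the step of a 1.2-fold lower number from compound 1 to compound 3 (0.07 log units; within the scatter) lies within the scatter, while a 2.0-fold higher number from compound 2 to compound 3 (0.31 log units; beyond the scatter) lies beyond it.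

Compound 4 `COc1cc(NC(C)CCCNC(=O)Nc2cccc(O)c2)c2ncccc2c1` differs from compound 3 in one place: hydroxy in place of chloro on an aromatic carbon. Among the compounds with values here, no measured step places a hydroxy group on this ring, so the only steps that bear on the change are the other substituent exchanges on the same phenyl, a 2.4-fold lower number from compound 1 to compound 2 (0.38 log units; beyond the scatter), a 1.2-fold lower number from compound 1 to compound 3 (0.07 log units; within the scatter) and a 2.0-fold higher number from compound 2 to compound 3 (0.31 log units; beyond the scatter), all of them modest or within the scatter. The expected step for compound 4 is therefore a 1.2-fold higher number from compound 3 to compound 4 (0.07 log units; within the scatter), with no movement beyond the scatter foreseen in either direction. The estimate for compound 4 in this assay is 20000 nM, with a range from 8000 nM to 50000 nM.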

Compound 4, half-maximal inhibitory concentration: 48000 nM
For compound 4 the middle estimate is 2.4-fold (0.38 log units) below the measured one, and the stated range covers the measured number.
By their numbers in this assay, from the lowest: compound 2; then compounds 3 and 1 (each within the scatter of the next); then compound 4.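

In this assay, hydroxy in place of chloro on this carbon gives a measurable rise, a 2.8-fold higher number from compound 3 to compound 4 (0.45 log units; beyond the scatter), whereas the three earlier compounds, which carry only fluoro, trifluoromethyl or chloro, span a narrower range. Within the data shown here, compound 4 now has the highest number of the set, with a 2.4-fold higher number from compound 1 to compound 4 (0.38 log units; beyond the scatter) and a 5.8-fold higher number from compound 2 to compound 4 (0.76 log units; beyond the scatter), although these two steps change the group and its place on the ring together, so only the step from compound 3 isolates the hydroxy exchange. No measurement shown explains the rise.

As far as these compounds go, whether the rise is specific to hydroxy remains open, since methoxy or an amine on the same carbon would test this directly. Also open, from the compounds shown here alone, is how hydroxy behaves in place of the fluoro of compound 1.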